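The source may report more compounds than this note shows. Statements on the series, on what has been measured and on what is new or still open speak of the compounds shown alone.

Compound 1 `O=C1O[C@H]([C@@H](O)Cn2cc(-c3ccc(Br)cc3)nn2)C(OCc2ccccc2)=C1OCc1ccccc1` is the most active of the two numbers at hand in an ADME assay on HFF cells (Homo sapiens) for cytotoxicity, read by MTT assay, with a stated time of 72 h; on this read-out higher numbers stand for weaker inhibition and lower numbers for stronger inhibition: compound 1 gives 5100 nM, whereas compound 2 `O=C1O[C@H]([C@@H](O)Cn2cc(-c3cc(C(F)(F)F)cc(C(F)(F)F)c3)nn2)C(OCc2ccccc2)=C1OCc1ccccc1`, the nearest neighbour, gives 80700 nM, a gap well beyond the usual scatter. Compound 3 `COc1ccccc1-c1cn(C/C=C2\OC(=O)C(OCc3ccccc3)=C2OCc2ccccc2)nn1` returns only a limit, > 100000 nM, so it is one of the values that sit at the limit of > 100000 nM in this assay, at which 1 of the 3 values shown sits, rather than a measured number.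

The step to compound 4 `COc1ccc(-c2cn(C[C@H](O)[C@H]3OC(=O)C(OCc4ccccc4)=C3OCc3ccccc3)nn2)cc1` is a single substituent swap, (methoxy in place of bromo on an aromatic carbon). Among the compounds with values here, no measured pair in this set isolates that change, so the outcome rests on expectation alone. The weaker numbers of compounds 2 and 3 suggest that compound 1 may be the exception rather than the rule; the step from compound 1 to compound 4 is expected to be a 2.9-fold higher number from compound 1 to compound 4 (0.47 log units; beyond the scatter). Compound 4 is therefore estimated at 15000 nM, with a plausible range from 4000 nM to 60000 nM.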

Compound 4, half-maximal inhibitory concentration: < 10 nM
Compound 4: no number, only a limit; the forecaster's own chance of this, stated with the estimate: 20%; at least 1500-fold (3.17 log units) between middle value and limit.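

The swap from 4-bromophenyl to 4-methoxyphenyl gives an at least 510-fold lower number from compound 1 to compound 4 (2.70 log units; beyond the scatter) in this assay, so this single place on the aromatic ring can move the read-out by a large margin. The earlier compounds shown here held no pair that isolated a change here. The value of compound 4 is a limit and not a number: the limit of < 10 nM in this assay, at which 1 of the 4 values shown sits.

Within the data shown here, with only this one pair, it stays open whether the shift belongs to the methoxy group alone or would also appear with a hydroxyl, an ethoxy group or an amine at this place. Whether it would carry over to the other compounds shown also stays open.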